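A few compounds are considered here, and "the series" means these few. Any claim that something is new, unique, unknown or untested is made for them only; others in the source may bear on it.

Of the compounds shown here, three sharing one core have been tested in a functional assay for inhibition of nuclear factor NF-kappa-B complex (Homo sapiens); on this read-out higher numbers stand for weaker inhibition and lower numbers for stronger inhibition. Compound 1 `COc1ccc2c(c1)OC(c1cc(OC)c(OC)c(OC)c1)C(C=O)=C2` gives 13500 nM. Compound 2 `CCOCC1=Cc2ccc(OC)cc2OC1c1cc(OC)c(OC)c(OC)c1` gives 21300 nM, and compound 3 `CCCC(=O)C1=Cc2ccc(OC)cc2OC1c1cc(OC)c(OC)c(OC)c1` gives 11700 nM. Compound 3 has the lowest of the three numbers, yet the steps of a 1.2-fold lower number from compound 1 to compound 3 (0.06 log units; within the scatter) and a 1.8-fold lower number from compound 2 to compound 3 (0.26 log units; within the scatter) both lie within the scatter, so the three cannot be told apart. Compound 4 `CCCCNC(=O)C1=Cc2ccc(OC)cc2OC1c1cc(OC)c(OC)c(OC)c1` is not yet measured; it differs from compound 3 by butylamino in place of propyl on a carbonyl carbon. Within the data shown here, the step of a 1.2-fold lower number from compound 1 to compound 3 (0.06 log units; within the scatter) is the only measured change on this carbonyl carbon, and it was small; the step of a 1.6-fold higher number from compound 1 to compound 2 (0.20 log units; within the scatter) on the double-bonded ring carbon was also small. No step beyond the scatter is therefore expected. Compound 4 is estimated at 12000 nM, within a range from 5000 nM to 30000 nM. This corresponds to an expected step of a 1.0-fold higher number from compound 3 to compound 4 (0.01 log units; within the scatter).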

Compound 4, half-maximal inhibitory concentration: 25500 nM
Estimate against measurement, compound 4: 2.1-fold (0.33 log units) below, and the stated range covers the measured number.
By their numbers in this assay, from the lowest: compounds 3, 1, 2 and 4 (each within the scatter of the next, the first and the last beyond it).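

In this assay this carbonyl carbon shows its first step beyond the scatter, with a 2.2-fold higher number from compound 3 to compound 4 (0.34 log units; beyond the scatter) when butylamino replaces propyl, a modest move toward weaker inhibition. Compound 4 stands apart only from compound 3, since a 1.9-fold higher number from compound 1 to compound 4 (0.28 log units; within the scatter) and a 1.2-fold higher number from compound 2 to compound 4 (0.08 log units; within the scatter) both stay within the scatter. No measured evidence bears on why the butylamino change gives this step. The compounds shown leave open whether the chain or the amide hydrogen matters, and how a propylamino or dimethylamino group on this carbonyl carbon would compare.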